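Phosphoramidate series: removing the benzoyl ester of compound 1

A few compounds are considered here, and "the series" means these few. Any claim that something is new, unique, unknown or untested is made for them only; others in the source may bear on it.

Compound 1 `O=C(O[C@H]1C[C@H](n2cc(F)c(=O)[nH]c2=O)O[C@@H]1COP(=O)(O)Oc1ccccc1)c1ccccc1` is the parent of this set. Among the compounds with values here, in a functional assay on Caco-2 cells (Homo sapiens) for cytotoxicity, read by MTT assay, with a stated time of 48 h (on this read-out higher numbers stand for weaker inhibition and lower numbers for stronger inhibition), compound 1 gives 1020 nM, the lowest of the two numbers measured so far. Within the data shown here, its only measured neighbour is compound 2 `O=C(O[C@H]1C[C@H](n2cc(F)c(=O)[nH]c2=O)O[C@@H]1COP(=O)(O)Oc1ccc2ncccc2c1)c1ccccc1`, which in this assay gives 2460 nM; the single measured step is a 2.4-fold higher number from compound 1 to compound 2 (0.38 log units; beyond the scatter), a change at the aryl oxygen of the phosphate.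

Compound 3 `O=c1[nH]c(=O)n([C@H]2C[C@H](O)[C@@H](COP(=O)(O)Oc3ccccc3)O2)cc1F` is not yet measured. It differs from compound 1 in one place: hydrogen in place of benzoyl on an oxygen on a saturated carbon. The measured step from compound 1 to compound 2 touches a different part of the molecule, the aryl group on the phosphate oxygen, and nothing measured here touches the benzoyl ester on the sugar oxygen. Hence no measured step bears on this change, and the only guide is that the one step seen in the set was modest in size. A modest change in this assay is therefore expected, direction uncertain, with a higher number judged somewhat more likely than a lower one. Compound 3 is expected to give 2000 nM, within a range of 700 nM to 6000 nM. The expected step is a 2.0-fold higher number from compound 1 to compound 3 (0.29 log units; within the scatter).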

Compound 3, half-maximal inhibitory concentration: 26600 nM
Compound 3: the middle estimate sits 13-fold (1.12 log units) below what was measured, and the stated range ends below it.
By their numbers in this assay, from the lowest: compound 1; then compound 2; then compound 3.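

In this assay the sugar oxygen is the more sensitive of the two places changed so far: benzoyloxy to hydroxy gives a 26-fold higher number from compound 1 to compound 3 (1.42 log units; beyond the scatter) and counts as a large step, while the change of aryl group on the phosphate oxygen gave only a 2.4-fold higher number from compound 1 to compound 2 (0.38 log units; beyond the scatter) and counts as modest. In this one pair, the benzoyl group goes with the lower number, so the ester cannot be treated as a neutral appendage on the core of compound 1. Nothing available explains the size of this step.

Going by these compounds, it remains open whether the benzoyl ring itself matters or whether another group on this oxygen would hold the lower number; an acetyl ester or a methyl ether in the same place would separate these two readings. Also open, on these data alone, is whether benzoyloxy to hydroxy gives a step of similar size when quinolin-6-yl replaces phenyl on the phosphate oxygen, as the change is seen here only with phenyl.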